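A few compounds are considered here, and "the series" means these few. Any claim that something is new, unique, unknown or untested is made for them only; others in the source may bear on it.

Of the compounds shown here, two have been measured so far, and both share one core. Compound 1 `N#Cc1ccc(O[C@H]2CN(S(=O)(=O)c3ccc(Cl)cc3Cl)C[C@@]2(O)CN)cc1F` carries an aminomethyl group, and in a physicochemical assay for solubility, in simulated intestinal fluid, with a stated time of 4 h (a higher number here means a more soluble compound, a lower number a less soluble compound), compound 1 gives 78 ug/mL. Compound 2 `N#Cc1ccc(O[C@H]2CN(S(=O)(=O)c3ccc(Cl)cn3)C[C@@]2(O)CO)cc1F` carries a hydroxymethyl group in that position; in this assay compound 2 gives 26 ug/mL, the lowest of the two numbers, and its gap to compound 1 lies beyond the scatter. Compound 3 `N#Cc1ccc(O[C@H]2CN(S(=O)(=O)c3ccc(Cl)cn3)C[C@@]2(O)CN)cc1F` has not yet been measured. It differs from compound 2 in a single place: amino in place of hydroxy on a saturated chain carbon bound to a saturated ring carbon. Among the compounds with values here, no measured pair shows this change on its own, so its effect is unknown. Still, compound 1, which carries the same aminomethyl group, gives 78 ug/mL, and an upward step in this assay of about a 2.3-fold higher number from compound 2 to compound 3 (0.36 log units; beyond the scatter) is expected, beyond the scatter. Compound 3 is therefore estimated at 60 ug/mL, within a range of 25 ug/mL to 150 ug/mL.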

Compound 3, solubility: > 1000 ug/mL
Compound 3 was reported as a limit; the forecaster's own chance of this, stated with the estimate: 5%; middle value at least 16-fold (1.22 log units) away from the limit.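

The step for amino in place of hydroxy on a saturated chain carbon bound to a saturated ring carbon can now be read on its own: in this assay it is an at least 38-fold higher number from compound 2 to compound 3 (1.58 log units; beyond the scatter), a large change from swapping a single heavy atom. The group on the sulfonyl sulfur also counts, since with aminomethyl kept, 5-chloropyridin-2-yl in place of 2,4-dichlorophenyl gives an at least 12-fold higher number from compound 1 to compound 3 (1.10 log units; beyond the scatter), so aminomethyl alone does not set the number. The reading for compound 3 is a limit of the assay and not a number: the limit of > 1000 ug/mL in this assay, at which 1 of the 3 values shown sits.

Still open, as far as these compounds go, is whether other groups in place of aminomethyl, such as dimethylaminomethyl, a carboxylic acid or a longer aminoethyl chain, would give a similar reading. Also open, from the compounds shown here alone, is how large the hydroxy-to-amino step would be with 2,4-dichlorophenyl on the sulfonyl sulfur.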